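Closing the acid chain into a ring on compound 3

This account rests on a few compounds, and the source may have more. Where it says the series, first, only, none or still open, it means among the compounds named here.

In a functional assay on ileum (Cavia porcellus) for antagonist activity at cysteinyl leukotriene receptor (Homo sapiens) (a lower number here means a stronger inhibitor, a higher number a weaker inhibitor), compound 1 `CCC(CC)(CC(=O)Nc1cccc(OCc2ccc3c(F)cccc3n2)c1)C(=O)O` gives 0.3 nM, compound 2 `CCC(CC)(CC(=O)Nc1cccc(OCc2ccc3ccc(OC)cc3n2)c1)C(=O)O` gives 80 nM; 80 nM (2 entries), and compound 3 `O=C(O)CCC(=O)Nc1cccc(OCc2ccc3ccc(F)cc3n2)c1` gives 200 nM. Compound 3 therefore stands at the highest of the two numbers shown, far from compound 1; the values of compounds 1 and 2 come from different structures and show only what each one gives. Compound 4 `O=C(CC1(C(=O)O)CCCC1)Nc1cccc(OCc2ccc3ccc(F)cc3n2)c1` changes the chain that carries the acid: 1-carboxycyclopentyl in place of carboxymethyl on a saturated chain carbon bound to a carbonyl carbon. Going by the values given here, no step between measured compounds matches this change, so the expected size rests on the overall pattern that compounds 1 and 2 sit well below compound 3. Compound 4 is expected to move down, with the step of a 20-fold lower number from compound 3 to compound 4 (1.30 log units; beyond the scatter) clearly beyond the scatter in this assay. Compound 4 is estimated at 10 nM, likely between 2 nM and 50 nM.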

Compound 4, half-maximal inhibitory concentration: 10 nM
For compound 4 middle estimate and measured number coincide at the digits printed; the measured number falls inside the stated range.
By their numbers in this assay, from the lowest: compound 1; then compound 4; then compound 3.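

Replacing carboxymethyl with 1-carboxycyclopentyl on a saturated chain carbon bound to a carbonyl carbon gives a 20-fold lower number from compound 3 to compound 4 (1.30 log units; beyond the scatter) in this assay. Going by these compounds alone, this is the only step here between compounds differing in one place, so it shows directly that this position responds strongly to the change, with the carboxylic acid kept and the core unchanged. Nothing shown explains the drop. Still open, as far as these compounds go, is whether a six-membered carbon ring would serve as well as the five-membered one, and whether a tetrazole could replace the carboxylic acid.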